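A few compounds are considered here, and "the series" means these few. Any claim that something is new, unique, unknown or untested is made for them only; others in the source may bear on it.

In an assay on membranes from brain for binding affinity to Monoacylglycerol lipase ABHD6 (Mus musculus), read by fluorescence, with stated times of 1 h and 30 min (a lower number here means a stronger inhibitor, a higher number a weaker inhibitor), compound 1 `CN(CCN(C)C(=O)n1cccn1)Cc1ccc(OCc2ccccc2)cc1` gives 530 nM. Compound 2 `CN(CCN(C)C(=O)n1cc(C#N)cn1)Cc1ccc(OCc2ccccc2)cc1` carries the change (cyano in place of hydrogen on an aromatic carbon), and in this assay compound 2 gives 320 nM. The step between them is a 1.7-fold lower number from compound 1 to compound 2 (0.22 log units; within the scatter). Compound 3 `O=C(N1CCN(C(c2ccc3ccccc3c2)c2ccc3ccccc3c2)CC1)n1cccn1` is built on a different core, and the difference between the two cores is not broken down here. In this assay compound 3 gives only > 100000 nM, which is a limit of the assay and not a number, as stated in the limit of > 100000 nM in this assay, at which 1 of the 3 values shown sits.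

Compound 4 `N#Cc1cnn(C(=O)N2CCN(C(c3ccc4ccccc4c3)c3ccc4ccccc4c3)CC2)c1` has not yet been measured in this assay. For the measured compounds named here, it differs from compound 3 by cyano in place of hydrogen on an aromatic carbon, the same change as the one made on compound 1, at the same kind of place. For this change the measured step was a 1.7-fold lower number from compound 1 to compound 2 (0.22 log units; within the scatter), and compound 3 already sits at the limit of > 100000 nM in this assay, at which 1 of the 3 values shown sits, so no large gain is expected. The step that the estimate means is expected to be a step that the limit leaves unreadable from compound 3 to compound 4. Compound 4 is therefore expected to give about 150000 nM, between 50000 nM and 600000 nM, most probably again only a limit.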

Compound 4, half-maximal inhibitory concentration: 560 nM
Beside the measured number, compound 4's estimate is 270-fold (2.43 log units) above it; the measured number lies below the stated range.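

In this assay, the change from 1H-pyrazol-1-yl to 4-cyano-1H-pyrazol-1-yl on the core of compound 3 gives an at least 170-fold lower number from compound 3 to compound 4 (2.25 log units; beyond the scatter). The same change therefore does not carry over from one core to the other at one size: the same change on two cores in this assay, a 1.7-fold lower number (0.22 log units; within the scatter) from compound 1 to compound 2 and an at least 170-fold lower number (2.25 log units; beyond the scatter) from compound 3 to compound 4, at least 100-fold (2.03 log units) apart, beyond the scatter of two such steps

Going by these compounds, compound 3 gives > 100000 nM, which is a limit of the assay and not a number; the full size of its step remains unknown, and the two cores show that the size of the step differs between them, not what in the cores sets that difference or whether a third core would follow either one.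

On these data alone, whether a methyl group or a carboxylic acid on the same aromatic carbon would behave as cyano does on either core remains open. Also open, as far as these compounds go, is which part of the core of compound 3 goes with the larger step, a question that a core carrying an amine on a longer chain could bear on.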